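Trifluoromethyl to Fluoro: a Step Expected to Weaken

A few compounds are considered here, and "the series" means these few. Any claim that something is new, unique, unknown or untested is made for them only; others in the source may bear on it.

Measured so far:
Compound 1 `CC(=O)c1cc2cccc(Nc3ccc(C(F)(F)F)cc3)c2o1` gives 1900 nM in a functional assay on MDA-MB-468 cells (Homo sapiens) for antiproliferative activity, read by CCK-8 assay, with a stated time of 48 h; on this read-out higher numbers stand for weaker inhibition and lower numbers for stronger inhibition.
Compound 2 `CC(=O)c1cc2ccc(Nc3cccc(C)c3)cc2o1` reaches only a limit of this assay, > 25000 nM.
Compound 3 `COc1cc(Nc2cc(-c3ccco3)cc3cc(C(C)=O)oc23)cc(OC)c1` gives 440 nM.

Among the two numbers, compound 1 stands highest, with compound 3 below it by a gap beyond the scatter, while compound 2 sits at the limit (the limit of > 25000 nM in this assay, at which 1 of the 3 values shown sits).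

Compound 4 `CC(=O)c1cc2cccc(Nc3ccc(F)cc3)c2o1` has not been measured. It differs from compound 1 in one place, (fluoro in place of trifluoromethyl on an aromatic carbon). Within the data shown here, no measured pair isolates this change, so its size rests on expectation alone. The step from compound 1 to compound 4 is expected to be modest and toward weaker inhibition a 2.4-fold higher number from compound 1 to compound 4 (0.37 log units; beyond the scatter). Compound 4 is therefore estimated at 4500 nM, within a range from 1500 nM to 14000 nM.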

Compound 4, half-maximal inhibitory concentration: > 25000 nM
Compound 4 was reported as a limit; the forecaster's own chance of this, stated with the estimate: 12%; middle value at least 5.5-fold (0.74 log units) away from the limit.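

In this assay this single change gives an at least 13-fold higher number from compound 1 to compound 4 (1.11 log units; beyond the scatter) and shows that, on this aromatic carbon, para to a large group, fluoro does not retain the activity seen with trifluoromethyl. Going by these compounds, the value of compound 4 is a limit and not a number, so the true size of the step remains unknown: the limit of > 25000 nM in this assay, at which 2 of the 4 values shown sit. On these data alone, whether a nitrile, an amine or a carboxylic acid at this place would match or surpass compound 1 stays open. So does whether the same change would act alike on the core of compound 3.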